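Piperazine Amides in HL-60 Cells: Expecting Compound 4

The source may report more compounds than this note shows. Statements on the series, on what has been measured and on what is new or still open speak of the compounds shown alone.

Measured so far:
Compound 1 `Cc1ccc(C)c(N2CCN(C(=O)c3oc(C)nc3-c3ccc(F)cc3)CC2)c1`: 358 nM
Compound 2 `COc1cccc(N2CCN(C(=O)c3oc(C)nc3-c3ccc(F)cc3)CC2)c1`: 112 nM
Compound 3 `COc1cccc(N2CCN(C(=O)c3oc(C)nc3-c3cccc(F)c3)CC2)c1`: "not active" (no number reported)

Of the compounds shown here, three sharing one amide-linked scaffold have been tested in a functional assay on HL-60 cells (Homo sapiens) for inhibition, read by MTT assay, with a stated time of 72 h; a lower number here means a stronger inhibitor, a higher number a weaker inhibitor. Compound 2 gives 112 nM. Compound 1 differs from it by one change, 2,5-dimethylphenyl in place of 3-methoxyphenyl on an amine nitrogen in a ring, and this brings a 3.2-fold higher number from compound 2 to compound 1 (0.50 log units; beyond the scatter). Compound 3 carries the same atoms as compound 2 joined differently, 3-fluorophenyl in place of 4-fluorophenyl on an aromatic carbon, and in this assay compound 3 is reported as "not active" (no number reported), so no number stands beside it.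

Compound 4 `Cc1ccc(C)c(N2CCN(C(=O)c3oc(C)nc3-c3cccc(F)c3)CC2)c1` has not yet been measured. It stands to compound 3 as compound 1 stands to compound 2: the change is 2,5-dimethylphenyl in place of 3-methoxyphenyl on an amine nitrogen in a ring, and the surroundings of the place are the same, so this is the same change. In compound 2 that change made a modest step toward a weaker inhibitor, a 3.2-fold higher number from compound 2 to compound 1 (0.50 log units; beyond the scatter). Since compound 3 already shows no measurable inhibition, compound 4 is expected to be weak as well, most likely beyond the range where a number is reported, because compound 3 gives "not active" (no number reported). The estimate for compound 4 in this assay is 20000 nM, expected to lie between 3000 nM and 100000 nM.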

Compound 4, half-maximal inhibitory concentration: 204 nM
Compound 4: middle estimate off by 98-fold (1.99 log units), on the high side, and the stated range ends above it.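

In this assay, as far as these compounds go, compound 4 gives (204 nM), while compound 3 is reported as "not active" with no number, so the change to 2,5-dimethylphenyl in place of 3-methoxyphenyl, which on the core of compound 2 brought (a 3.2-fold higher number from compound 2 to compound 1 (0.50 log units; beyond the scatter)), cannot be read as a step on the core of compound 3, and its size there stays unknown. What the new step does show concerns the other change: with 2,5-dimethylphenyl on the amine nitrogen, 3-fluorophenyl in place of 4-fluorophenyl gives (a 1.8-fold lower number from compound 1 to compound 4 (0.24 log units; within the scatter)), whereas with 3-methoxyphenyl the same swap leads from compound 2 at (112 nM) to compound 3, reported as "not active", so that swap does not read the same in the two pairs. Nothing available here bears on why the two pairs part ways.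

The compounds shown leave open whether a plain phenyl or a 4-chlorophenyl on the shared core would follow the pair holding 2,5-dimethylphenyl or the pair holding 3-methoxyphenyl. They also leave open how a plain phenyl on the amine nitrogen would behave with either fluorophenyl.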